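Swapping Trifluoromethyl for Nitro on a Porcupine Inhibitor Core

The source may report more compounds than this note shows. Statements on the series, on what has been measured and on what is new or still open speak of the compounds shown alone.

For the measured compounds named here, compound 2 `O=C(CNC(=O)c1nn(-c2ccccc2)c(=O)c2ccccc12)Nc1nc2ccc(C(F)(F)F)cc2s1` is one of three compounds measured in an assay on L cells for inhibition of Protein-serine O-palmitoleoyltransferase porcupine (Mus musculus), read by reporter gene assay, with a stated time of 24 h (a lower number here means that less compound is needed, a higher number that more compound is needed for the effect), where compound 2 gives 110 nM. This is the highest of the three numbers. Its nearest neighbour is compound 3 `O=C(CNC(=O)c1nn(-c2ccc(F)cc2)c(=O)c2ccccc12)Nc1nc2ccc(C(F)(F)F)cc2s1`, which gives 90 nM; the step of a 1.2-fold lower number from compound 2 to compound 3 (0.09 log units; within the scatter) comes from fluoro in place of hydrogen on an aromatic carbon and stays within the scatter. Far away stands compound 1 `O=C(CSc1nc2c(c(=O)n1-c1ccccc1)SCC2)Nc1ccc(-c2ccccc2)nc1`, built on a different core, which gives 0.3 nM.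

Compound 4 `O=C(CNC(=O)c1nn(-c2ccccc2)c(=O)c2ccccc12)Nc1nc2ccc([N+](=O)[O-])cc2s1` differs from compound 2 in a single place: nitro in place of trifluoromethyl on an aromatic carbon. Going by the values given here, no measured step touches this part of the shared core. Among the compounds with values here, the one step that is known, from compound 2 to compound 3, alters a different ring and does not rise above the scatter, so it carries no information about exchanging the trifluoromethyl group. Compound 1 is too different in its core to guide the change. Without a precedent, no movement beyond the scatter is expected in this assay, in either direction. Compound 4 is therefore estimated at 110 nM, with a range from 35 nM to 350 nM. The expected step is no change at the digits printed from compound 2 to compound 4 (within the scatter).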

Compound 4, half-maximal effective concentration: 240 nM
Compound 4: middle estimate off by 2.2-fold (0.34 log units), on the low side, within the range that was stated.
By their numbers in this assay, from the lowest: compound 1; then compounds 3 and 2 (each within the scatter of the next); then compound 4.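

Exchanging trifluoromethyl for nitro gives a 2.2-fold higher number from compound 2 to compound 4 (0.34 log units; beyond the scatter) in this assay and shows that this aromatic carbon of the shared core is sensitive to the group it carries, although the step is modest and the number moves toward more compound being needed. The only earlier step, a 1.2-fold lower number from compound 2 to compound 3 (0.09 log units; within the scatter), changed a different part of the molecule and stayed within the scatter, which makes this the first step among these close relatives to rise beyond it. The two groups differ in their atoms, and nitro brings hydrogen-bond acceptors that trifluoromethyl lacks, but nothing available here ties any such difference to the higher number.

With only trifluoromethyl and nitro compared at this carbon, the compounds shown leave open how an amine, a carboxylic acid, a methoxy group or a plain hydrogen would read there, and whether any group could bring the number lower than trifluoromethyl does. On these data alone, it also remains open whether the same exchange would give a step of similar size with fluoro on the other ring, as in compound 3.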